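Taking the 4-fluorobenzyl off an amide-type nitrogen

This account rests on a few compounds, and the source may have more. Where it says the series, first, only, none or still open, it means among the compounds named here.

In an ADME assay on cells (Hepatocyte, Rattus norvegicus) for pharmacokinetics, read by LC-MS, with a stated time of 90 min, tested at 1 uM (on this read-out higher numbers stand for fast clearance and lower numbers for slow clearance), compound 1 (`COC(=O)N(Cc1ccccc1F)c1c(N)nc(-c2nn(Cc3ccccc3F)c3ncccc23)nc1N`) gives 53.3 mL/min/kg, and compound 2 (`COC(=O)N(Cc1ccc(F)cc1)c1c(N)nc(-c2nn(Cc3ccccc3F)c3ncccc23)nc1N`) gives 40 mL/min/kg. These two numbers lie within the usual scatter of each other, so compound 2 stands level with compound 1 on this evidence. Among the measured compounds shown here, the only measured step, a 1.3-fold lower number from compound 1 to compound 2 (0.12 log units; within the scatter), exchanges 2-fluorophenyl for 4-fluorophenyl and stays within the scatter. Compound 3 (`COC(=O)Nc1c(N)nc(-c2nn(Cc3ccccc3F)c3ncccc23)nc1N`) has hydrogen in place of 4-fluorobenzyl on an amide-type nitrogen. This removes a whole group, whereas the measured step only relocated a fluorine, so that step says little about what to expect here. For the measured compounds named here, no measured step removes this group, which makes the direction a judgement. The expected change is towards a lower number, an estimated 1.6-fold lower number from compound 2 to compound 3 (0.20 log units; within the scatter). For compound 3 the estimate is 25 mL/min/kg, with an expected range of 10 mL/min/kg to 55 mL/min/kg.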

Compound 3, clearance: 1.67 mL/min/kg
Compound 3: the middle estimate sits 15-fold (1.18 log units) above what was measured; the measured number lies below the stated range.
By their numbers in this assay, from the lowest: compound 3; then compounds 2 and 1 (each within the scatter of the next).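

In this assay the steps of a 24-fold lower number from compound 2 to compound 3 (1.38 log units; beyond the scatter) and a 32-fold lower number from compound 1 to compound 3 (1.50 log units; beyond the scatter) both come from putting hydrogen on this amide-type nitrogen in place of a fluorobenzyl group. Set against a 1.3-fold lower number from compound 1 to compound 2 (0.12 log units; within the scatter) for relocating the fluorine, this shows that the presence of a fluorobenzyl group on this nitrogen counts for far more in the clearance reading than where its fluorine sits. Nothing measured here gives a reason for so large a drop.

As far as these compounds go, what stays open is whether the low number needs the amide hydrogen itself or only the absence of the aromatic ring. A methyl group or a plain benzyl group without fluorine on this nitrogen would help separate those two possibilities, and a longer chain would show how much of the group can return before the number climbs again.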